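The compounds below may be only part of what the source reports. "The series", "measured", "known", "first", "only" and "open" are said of these compounds alone.

Measured in a functional assay on LoVo cells (Homo sapiens) for antiproliferative activity, read by MTT assay, with a stated time of 72 h; a higher number here means a weaker inhibitor, a lower number a stronger inhibitor:
- compound 1 `COc1cccc(/C=C2\CCC/C(=C\c3cc(OC)c(OC)c(OC)c3)C2=O)c1OC`: 2600 nM
- compound 2 `COc1cc(/C=C2\CCC/C(=C\c3ccc(O)c(O)c3)C2=O)cc(OC)c1OC`: 2700 nM
- compound 3 `COc1ccccc1/C=C1\CCC/C(=C\c2cc(OC)c(OC)c(OC)c2)C1=O`: 1100 nM

Compound 1 holds the second highest of these three numbers. Compound 4 `COc1ccc(/C=C2\CCC/C(=C\c3cc(OC)c(OC)c(OC)c3)C2=O)cc1OC` has not been measured, and it differs from compound 1 as follows: 3,4-dimethoxyphenyl in place of 2,3-dimethoxyphenyl on a double-bonded chain carbon bound to a double-bonded ring carbon. In short, 3,4-dimethoxyphenyl stands in place of 2,3-dimethoxyphenyl on a double-bonded chain carbon bound to a double-bonded ring carbon.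

The closest guide is compound 2, which also carries a 3,4-pattern, as 3,4-dihydroxyphenyl, and there the swap gave a 1.0-fold higher number from compound 1 to compound 2 (0.02 log units; within the scatter). Replacing a methoxy with hydrogen is a different change, and it gave a modest 2.4-fold lower number from compound 1 to compound 3 (0.37 log units; beyond the scatter). No step beyond the scatter is therefore expected, and the estimate is a 1.3-fold lower number from compound 1 to compound 4 (0.11 log units; within the scatter). Compound 4 is expected at 2000 nM, within an estimated range of 800 nM to 5000 nM.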

Compound 4, half-maximal inhibitory concentration: 1700 nM
Estimate against measurement, compound 4: 1.2-fold (0.07 log units) above; the measured number falls inside the stated range.
By their numbers in this assay, from the lowest: compounds 3, 4, 1 and 2 (each within the scatter of the next, the first and the last beyond it).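

In this assay, the same atoms rearranged as 3,4-dimethoxyphenyl in place of 2,3-dimethoxyphenyl give a 1.5-fold lower number from compound 1 to compound 4 (0.18 log units; within the scatter), so this change at the double-bonded chain carbon stays inside the scatter. Compound 4 also stays within the scatter of both other compounds, with a 1.5-fold higher number from compound 3 to compound 4 (0.19 log units; within the scatter) and a 1.6-fold lower number from compound 2 to compound 4 (0.20 log units; within the scatter), so it separates from none of them. No measured evidence is available to explain these numbers. Going by these compounds, whether an amine or a carboxylic acid on this aromatic ring, or a longer chain in place of a methoxy, would shift the number remains open.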